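Sulfamoyl in place of acetamido on the anilide of compound 3

This account rests on a few compounds, and the source may have more. Where it says the series, first, only, none or still open, it means among the compounds named here.

Measured compounds in an in vitro assay on Sf21 cells for inhibition of high affinity 3',5'-cyclic-AMP phosphodiesterase 7A (Homo sapiens), read by scintillation proximity assay, with a stated time of 30 min; a higher number here means a weaker inhibitor, a lower number a stronger inhibitor:
compound 1 `CC(=O)Nc1ccc(NC(=O)c2cn(Cc3c(F)cccc3F)c3ccc(=O)[nH]c3c2=O)cc1` gives 24 nM
compound 2 `COc1cc(NC(=O)c2cn(Cc3ccc(F)cc3Cl)c3ccc(=O)[nH]c3c2=O)cc(OC)c1OC` gives 192 nM
compound 3 `CC(=O)Nc1ccc(NC(=O)c2cn(Cc3c(F)cccc3Cl)c3ccc(=O)[nH]c3c2=O)cc1` gives 17 nM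

Compound 3 stands at the low end of the three numbers. Its nearest neighbour is compound 1: the step of a 1.4-fold lower number from compound 1 to compound 3 (0.15 log units; within the scatter) lies within the scatter, so the two cannot be ordered. Compound 2, which differs from compound 3 in more than one place, gives a number beyond the scatter of compound 3, and nothing more is drawn from that pair.

Compound 4 `NS(=O)(=O)c1ccc(NC(=O)c2cn(Cc3c(F)cccc3Cl)c3ccc(=O)[nH]c3c2=O)cc1` is not yet measured. It differs from compound 3 by sulfamoyl in place of acetamido on an aromatic carbon.

Among the measured compounds shown here, no measured step bears on this change. For the measured compounds named here, the only single-place step in the set, the halogen exchange from compound 1 to compound 3, touches a different part of the molecule and was itself within the scatter. The data therefore give no direction for the exchange of the acetamido for the sulfamoyl, and the expectation rests on the unchanged remainder of compound 3.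

In this assay compound 4 is expected to give 30 nM, in the range 8 nM to 120 nM. The expected step of a 1.8-fold higher number from compound 3 to compound 4 (0.25 log units; within the scatter) is thus no larger than the scatter, with a wide margin either way.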

Compound 4, half-maximal inhibitory concentration: 20 nM
Compound 4: middle estimate off by 1.5-fold (0.18 log units), on the high side; the measured number falls inside the stated range.
By their numbers in this assay, from the lowest: compounds 3, 4 and 1 (each within the scatter of the next); then compound 2.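

In this assay, exchanging 4-acetamidophenyl for 4-sulfamoylphenyl gives a 1.2-fold higher number from compound 3 to compound 4 (0.07 log units; within the scatter) and so leaves the two compounds unordered. Among the compounds shown here, this is the only step at this position, on the aromatic carbon para to a large group, and it shows that the acetamido group of compound 3 can give way to sulfamoyl, with its sulfur and extra hydrogen-bond acceptor, without a change beyond the scatter. No measurement at hand bears on why the two groups read alike.

A single exchange does not describe the position as a whole: an amine, a carboxylic acid, a methylsulfonyl group or a longer chain on the sulfamoyl nitrogen could each read differently at the same carbon. Going by these compounds, it also remains open whether the sulfamoyl group reads the same with the benzyl group of compound 1, or with a halogen pattern further from those of compound 1 and compound 3.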